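A few compounds are considered here, and "the series" means these few. Any claim that something is new, unique, unknown or untested is made for them only; others in the source may bear on it.

For the measured compounds named here, in a functional assay on DU-145 cells (Homo sapiens) for inhibition, read by trypan blue exclusion, with a stated time of 96 h (a lower number here means a stronger inhibitor of growth, a higher number a weaker inhibitor of growth), two compounds have numbers so far. Compound 1 `COc1ccc(/C=C(\C(=O)c2ccc(Br)cc2)S(=O)(=O)Cc2ccc(F)cc2)cc1` gives 25000 nM, while compound 2 `COc1ccc(S(=O)(=O)/C(=C/c2ccc(Br)cc2)C(=O)c2ccc(Br)cc2)cc1` gives 6000 nM. This is the lower of the two numbers, and the gap between them lies beyond the usual scatter. Still unmeasured, compound 3 `O=C(/C(=C\c1ccc(Br)cc1)S(=O)(=O)Cc1ccc(F)cc1)c1ccc(Br)cc1` differs from compound 2 in one place, with 4-fluorobenzyl in place of 4-methoxyphenyl on a sulfonyl sulfur. Going by the values given here, no measured pair shows this change alone, so its size in this assay cannot be read directly from the data. The only hint is that 4-fluorobenzyl also stands on the sulfonyl sulfur of compound 1, which has the higher number at 25000 nM. A small step towards a higher number, meaning a weaker inhibitor of growth, is therefore expected, and it may not clear the scatter. The expected size of the change is a 1.5-fold higher number from compound 2 to compound 3 (0.18 log units; within the scatter). For compound 3 the estimated value is 9000 nM, with an expected range from 2500 nM to 30000 nM.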

Compound 3, concentration for 50% growth inhibition: 25000 nM
The estimate for compound 3 lay 2.8-fold (0.44 log units) below the measured number; low and high end bracket the measured number.
By their numbers in this assay, from the lowest: compound 2; then compounds 1 and 3 (each within the scatter of the next).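

With the shared core otherwise held constant in this assay, replacing the 4-methoxyphenyl group on the sulfonyl sulfur with 4-fluorobenzyl gives a 4.2-fold higher number from compound 2 to compound 3 (0.62 log units; beyond the scatter) and provides a direct reading of this change, which shows that the group at this position can shift growth inhibition beyond the scatter. With 4-fluorobenzyl on the sulfonyl sulfur, placing bromo instead of methoxy on an aromatic carbon gives no change at the digits printed from compound 1 to compound 3 (within the scatter) and thus shows no measurable difference for that exchange in this setting. The data shown offer no measurement that explains either result.

The compounds shown leave open which part of the exchange on the sulfonyl sulfur carries the larger step, a question that 4-methoxybenzyl and 4-fluorophenyl at this position could help separate. They also leave open whether the exchange of bromo for methoxy would read the same with 4-methoxyphenyl on the sulfonyl sulfur, and how a simple alkyl chain such as ethyl would compare there.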